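Ring size at the amine of an adenosine receptor A3 ligand

This account rests on a few compounds, and the source may have more. Where it says the series, first, only, none or still open, it means among the compounds named here.

Measured so far:
compound 1 `Cn1c(-c2ccccc2)nc2c(NC3CCCCC3)ncnc21` 2370 nM
compound 2 `CCCn1c(-c2ccccc2)nc2c(NC3CCCC3)ncnc21` 749 nM

In an assay on CHO cells for displacement of a labelled ligand from adenosine receptor A3 (Homo sapiens), read by scintillation counting, with a stated time of 3 h (on this read-out lower numbers stand for stronger inhibition and higher numbers for weaker inhibition), compound 2 gives the lowest of the two numbers shown; compound 1 gives a number beyond the scatter above it. Compound 3 `CCCn1c(-c2ccccc2)nc2c(NC3CCCCC3)ncnc21` has not been measured. It differs from compound 2 by cyclohexyl in place of cyclopentyl on a nitrogen on an aromatic ring — cyclohexyl in place of cyclopentyl on a nitrogen on an aromatic ring. Among the measured compounds shown here, no measured pair isolates this change, so the expected step of a 1.5-fold higher number from compound 2 to compound 3 (0.17 log units; within the scatter) is small, toward a somewhat higher number, and may not exceed the scatter. Compound 3 is expected to give about 1100 nM in this assay, within 400 nM to 3000 nM.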

Compound 3, inhibition constant: 2360 nM
Compound 3: the middle estimate sits 2.1-fold (0.33 log units) below what was measured; measured number inside the range.
By their numbers in this assay, from the lowest: compound 2; then compounds 3 and 1 (each within the scatter of the next).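

In this assay, cyclohexyl in place of cyclopentyl on a nitrogen on an aromatic ring gives a 3.2-fold higher number from compound 2 to compound 3 (0.50 log units; beyond the scatter), so this position responds to a change in ring size. With cyclohexyl held fixed, ethyl in place of hydrogen on a saturated chain carbon bound to an aromatic nitrogen gives a 1.0-fold lower number from compound 1 to compound 3 (0.00 log units; within the scatter), so that change shows no effect beyond the scatter. Nothing measured here explains either step. Still open, going by these compounds, is how cyclobutyl or an open butyl chain would read on this nitrogen, and whether the ethyl change would count for as little with cyclopentyl in place.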